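Cytotoxicity notes: compound 3 to compound 4

The compounds below may be only part of what the source reports. "The series", "measured", "known", "first", "only" and "open" are said of these compounds alone.

Measured so far in an ADME assay on MT2 cells (Homo sapiens) for cytotoxicity, read by XTT assay, with a stated time of 4 days; on this read-out higher numbers stand for lower toxicity in this test and lower numbers for higher toxicity in this test:
Compound 1 `Cc1ccc(C)n1-c1cccc(-c2nnn[nH]2)c1` gives 250000 nM.
Compound 2 `Cc1cc(C=C(C#N)C#N)c(C)n1-c1cccc(-c2nnn[nH]2)c1` reaches only the limit of the test, > 400000 nM.
Compound 3 `Cc1cc(/C=C2\SC(=S)N(c3cccc(C(F)(F)F)c3)C2=O)c(C)n1-c1cccc(-c2nnn[nH]2)c1` gives 15800 nM.

Compound 3 holds the lowest of the two real numbers in this assay; the number of compound 1 stands higher, and the value of compound 2 is a limit and not a number, noted as the limit of > 400000 nM in this assay, at which 1 of the 3 values shown sits. Compound 4 `Cc1cc(/C=C2\SC(=S)N(c3cccc([N+](=O)[O-])c3)C2=O)c(C)n1-c1cccc(-c2nnn[nH]2)c1` is not yet measured. It differs from compound 3 by nitro in place of trifluoromethyl on an aromatic carbon.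

Among the measured compounds shown here, only one step has both ends measured: an at least 1.6-fold higher number from compound 1 to compound 2 (0.20 log units; that floor lies within the scatter). That step concerns a different position and a different group, and its floor lies within the scatter, so it says little about the exchange of nitro for trifluoromethyl. For the measured compounds named here, no measured pair shows this exchange, and no evidence beyond the scatter is available for it. The working expectation is therefore no step beyond the scatter in this assay, in either direction, which gives for compound 4 an estimated no change at the digits printed from compound 3 to compound 4 (within the scatter). Compound 4 is thus expected near 15800 nM, with a range from 6000 nM to 40000 nM.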

Compound 4, half-maximal cytotoxic concentration: 77000 nM
For compound 4 the middle estimate is 4.9-fold (0.69 log units) below the measured one, outside the stated range (above it).
By their numbers in this assay, from the lowest: compound 3; then compound 4; then compound 1. At a limit, above all of these: compound 2.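

In this assay the group on the six-membered aromatic ring of carbon only, meta to a large group, does not leave the read-out unchanged: nitro in place of trifluoromethyl gives a 4.9-fold higher number from compound 3 to compound 4 (0.69 log units; beyond the scatter) and is the only step shown that lies beyond the scatter, moving towards lower toxicity in this test. The exchange does not return the number to that of the smaller parent, as compound 4 at 77000 nM still ranks below compound 1 at 250000 nM, so the change from 3-(trifluoromethyl)phenyl to 3-nitrophenyl recovers only part of the distance between these compounds. Nothing among the measurements shown accounts for the size or direction of this step.

With only trifluoromethyl and nitro shown at this place, it remains open whether the number would move further with an amine, a carboxylic acid or a methoxy group there, or whether nitro is a special case. Among the compounds shown here, also open is whether the same exchange gives a step of similar size and direction on a core other than the one shared by compound 3 and compound 4.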